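Shortening the side chain: from protected amine to isopropyl

The compounds below may be only part of what the source reports. "The series", "measured", "known", "first", "only" and "open" are said of these compounds alone.

The series shares one core, with variation only at the amino acid residue of the benzyl ester. Compound 1 `CC[C@H](C)[C@H](NC(=O)CN(c1ncnc2c1ncn2C1CCCCO1)C1CC1)C(=O)OCc1ccccc1` carries a sec-butyl group and gives 27.4% in a functional assay on the whole organism (Tail, strain ICR) with Mus musculus as the target, in the tail flick test, with a stated time of 60 min, at a dose of 25 umol/kg by the oral route; a lower number here means a weaker effect, a higher number a stronger effect of the compound at the dose given. Compound 2 `CC(C)(C)OC(=O)NCCCC[C@H](NC(=O)CN(c1ncnc2c1ncn2C1CCCCO1)C1CC1)C(=O)OCc1ccccc1` carries a 4-((tert-butoxycarbonyl)amino)butyl group in its place and gives 32.7% in this assay; the step of a number 5.3 percentage points higher from compound 1 to compound 2 (within the scatter) is the only measured one, and it lies within the scatter, so compound 2 cannot be separated from compound 1 on these numbers.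

Compound 3 `CC(C)C[C@H](NC(=O)CN(c1ncnc2c1ncn2C1CCCCO1)C1CC1)C(=O)OCc1ccccc1` is the unmeasured member. Its difference from compound 2 is isopropyl in place of 3-((tert-butoxycarbonyl)amino)propyl on a saturated chain carbon, two bonds along the chain from an amide-type nitrogen and a carbonyl carbon. Within the data shown here, the single measured step bears on this change only loosely: exchanging a short branched alkyl for the protected aminobutyl chain moved the read-out by an amount within the scatter, and the return to a short branched alkyl in compound 3 is therefore expected to move it by little. The estimated step of a number 4.7 percentage points lower from compound 2 to compound 3 (within the scatter) is expected to stay within the scatter. Compound 3 is thus expected to give about 28% in this assay, within a range from 15% to 42%.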

Compound 3, a percentage reported as activity, at one dose (the size of the read-out at that dose, not a potency): 34.2%
Compound 3: the middle estimate sits 6.2 percentage points below what was measured, and the stated range covers the measured number.
By their numbers in this assay, from the lowest: compounds 1, 2 and 3 (each within the scatter of the next).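

With compound 3 this position has held three quite different side chains, and none of the steps between them leaves the scatter in this assay. Exchanging the long protected chain, with its 11 heavy atoms, for the 3 heavy atoms of isopropyl gives a number 1.5 percentage points higher from compound 2 to compound 3 (within the scatter) and so shows that the tert-butoxycarbonyl-protected amine can be removed entirely from this chain without a change that these numbers can resolve, while the exchange between the two short branched groups, isobutyl in place of sec-butyl, gives a number 6.8 percentage points higher from compound 1 to compound 3 (within the scatter) and so leaves the shift of the branch point unresolved as well. No measurement at hand offers an explanation for these readings.

On these data alone, whether a free amine at the end of the butyl chain, a carboxylic acid or a benzyl group on this carbon would carry the read-out beyond the scatter remains open. Also open, as far as these compounds go, is whether the three compounds, which cannot be told apart at this single dose and time, would separate at other doses or times.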